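Replacing an aryl sulfonyl with a urea-bearing chain

The source may report more compounds than this note shows. Statements on the series, on what has been measured and on what is new or still open speak of the compounds shown alone.

In an ADME assay on microsomes from liver (Rattus norvegicus) for metabolic stability, with a stated time of 10 min (on this read-out lower numbers stand for a less stable compound and higher numbers for a more stable compound), compound 3 `O=C(NS(=O)(=O)c1ccc(F)cc1)c1ccc(Nc2nc(NC3(c4ccc(Cl)cc4)CC3)nc(OCC(F)(F)F)n2)cc1` gives 99%, the second highest of the three numbers. Compound 1 `O=C(NS(=O)(=O)c1ccccc1)c1ccc(Nc2nc(NC3(c4ccc(Cl)cc4)CC3)nc(OCC(F)(F)F)n2)cc1` gives 100% in this assay, and the step of a number 1 percentage points lower from compound 1 to compound 3 (within the scatter) is within the scatter. Among the measured compounds shown here, compound 2 `CCCCCNc1nc(Nc2ccc([N+](=O)[O-])cc2)nc(OCC(F)(F)F)n1` gives 35% in this assay, far below compound 3; it differs from compound 3 in several places at once, so its two values show only that the two compounds lie apart. Compound 4 `CC(C)NC(=O)NCCS(=O)(=O)NC(=O)c1ccc(Nc2nc(NC3(c4ccc(Cl)cc4)CC3)nc(OCC(F)(F)F)n2)cc1` has not yet been measured in this assay. The change from compound 3 is 2-((isopropylcarbamoyl)amino)ethyl in place of 4-fluorophenyl on a sulfonyl sulfur. For the measured compounds named here, no measured step follows this kind of change: the only single-point step, from compound 1 to compound 3, swaps fluoro for hydrogen on an aromatic carbon and stays within the scatter, and it says nothing about exchanging the 4-fluorophenyl for the 2-((isopropylcarbamoyl)amino)ethyl group. Because compound 3 gives 99% and compound 1 gives 100%, compound 4 is expected to remain high, but with a wider range downward, estimated at 85% (from 60% to 100%). That expectation corresponds to a step of a number 14 percentage points lower from compound 3 to compound 4 (beyond the scatter).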

Compound 4, percent of the compound remaining: 97%
Beside the measured number, compound 4's estimate is 12 percentage points below it; low and high end bracket the measured number.
By their numbers in this assay, from the lowest: compound 2; then compounds 4, 3 and 1 (each within the scatter of the next).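

In this assay, the 2-((isopropylcarbamoyl)amino)ethyl chain in place of 4-fluorophenyl on the sulfonyl sulfur gives a number 2 percentage points lower from compound 3 to compound 4 (within the scatter), and the same chain in place of phenyl gives a number 3 percentage points lower from compound 1 to compound 4 (within the scatter). The earlier step changed only a hydrogen to fluoro on the aromatic ring, whereas these steps remove the whole six-membered aromatic ring and bring in an open chain with 2 hydrogen-bond donors, and the read-out still does not move beyond the scatter. Nothing available accounts for this result.

The compounds shown leave open whether a simple alkyl chain, a carboxylic acid or an amine on the same sulfonyl sulfur would hold the number as well. They also leave open whether the urea matters here, or whether a shorter or longer link to it would serve equally.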